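Moving a Chlorine Atom on a Thioether Benzyl Group

A few compounds are considered here, and "the series" means these few. Any claim that something is new, unique, unknown or untested is made for them only; others in the source may bear on it.

Compound 1 `COc1ccc(C2N=C(SCc3ccccc3Cl)NC(C)=C2C(=O)Nc2ccc(F)cc2)cc1OC` and compound 2 `COc1ccc(C2N=C(SCc3cccc(Cl)c3)NC(C)=C2C(=O)Nc2ccc(F)cc2)cc1OC` share one core and differ in a single place. In a functional assay on the whole organism (artery, strain albino) with Rattus norvegicus as the target, with a stated time of 720 min, at a dose of 10 mg/kg by the oral route (a lower number here means less inhibition, a higher number more inhibition at the dose given (going by the name of the read-out)), compound 1 gives 23.2%, and compound 2 gives 15.5%. The change between them is 3-chlorophenyl in place of 2-chlorophenyl on a saturated chain carbon bound to a sulfur and it produced a number 7.7 percentage points lower from compound 1 to compound 2 (within the scatter).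

Compound 3 `CC1=C(C(=O)Nc2ccc(Br)cc2)C(c2ccc(Cl)cc2Cl)N=C(SCc2ccccc2Cl)N1` is built on a different core; the difference between the cores of compound 1 and compound 3 is not broken down here. In this assay compound 3 gives 20.6%, a value that sits within the scatter of both compound 1 and compound 2, so no ranking among the three is warranted.

Compound 4 `CC1=C(C(=O)Nc2ccc(Br)cc2)C(c2ccc(Cl)cc2Cl)N=C(SCc2cccc(Cl)c2)N1` stands to compound 3 as compound 2 stands to compound 1: the change is 3-chlorophenyl in place of 2-chlorophenyl on a saturated chain carbon bound to a sulfur, made at the same place, so it is the same change seen once before. For the measured compounds named here, the expected step is a number 6.6 percentage points lower from compound 3 to compound 4 (within the scatter), small because the only earlier instance gave a number 7.7 percentage points lower from compound 1 to compound 2 (within the scatter), a step within the scatter. For compound 4 the estimated value is 14%, expected to fall between 3% and 26%.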

Compound 4, a percentage reported as inhibition, in the whole organism at one dose (the size of the read-out at that dose, not a potency): 11.3%
The estimate for compound 4 lay 2.7 percentage points above the measured number; measured number inside the range.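

In this assay, putting 3-chlorobenzyl in place of 2-chlorobenzyl on the sulfur gives a number 9.3 percentage points lower from compound 3 to compound 4 (within the scatter), and this step can be set beside the one seen on the other core: the same change on two cores in this assay, a number 7.7 percentage points lower (within the scatter) from compound 1 to compound 2 and a number 9.3 percentage points lower (within the scatter) from compound 3 to compound 4, 1.6 percentage points apart, within the scatter of two such steps. As far as these two pairs can tell, the change carries from one core to the other with no sign that the core alters the size of the step. They do not show that the change itself has a real effect, as each step on its own stays within the scatter, and two cores say nothing about how it would behave on any further core.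

The compounds shown leave open how this assay would respond if the chlorobenzyl group on the sulfur gave way to a plain benzyl group, a longer chain or an amine. They also leave open whether a step clearly beyond the scatter would carry from one core to another as closely as this one does.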